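Thiophene in Place of Fluorophenyl on a Shared Amide

The source may report more compounds than this note shows. Statements on the series, on what has been measured and on what is new or still open speak of the compounds shown alone.

compound 1, `O=C(CCCCCCc1ccccc1)N1CCCC1`: 12900 nM
compound 2, `O=C(CCc1ccc(-c2cccc(F)c2)cc1)N1CCCC1`: 1800 nM

Of the compounds shown here, two with the same core have been tested in an assay on HEK293 cells for inhibition of N-acylethanolamine-hydrolyzing acid amidase (Rattus norvegicus), read by LC-MS, with a stated time of 30 min; a lower number here means a stronger inhibitor, a higher number a weaker inhibitor. Compound 1 gives 12900 nM, and compound 2 gives 1800 nM, the lower of the two numbers; the gap between them lies beyond the usual scatter of the measurement, so compound 2 is the stronger inhibitor of the pair.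

Compound 3, `O=C(CCc1ccc(-c2cccs2)cc1)N1CCCC1`, has not been measured yet. It differs from compound 2 in one place: thiophen-2-yl in place of 3-fluorophenyl on an aromatic carbon. Within the data shown here, no measured pair shows what this particular change does to the number, so the expectation rests on the two values above and on the size of the change itself.

The step is expected to be modest, around a 1.4-fold higher number from compound 2 to compound 3 (0.14 log units; within the scatter), that is, no change beyond the scatter or a small move toward a weaker inhibitor. Compound 3 is therefore estimated at 2500 nM, with a likely range from 800 nM to 8000 nM.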

Compound 3, half-maximal inhibitory concentration: > 100000 nM
Compound 3: only a limit was reported; the forecaster's own chance of this, stated with the estimate: 5%; middle value at least 40-fold (1.60 log units) from the limit.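

Replacing 3-fluorophenyl with thiophen-2-yl on this aromatic carbon is far from a small edit in this assay: it gives an at least 55-fold higher number from compound 2 to compound 3 (1.74 log units; beyond the scatter). Compounds 1 and 2 differ in more than one place, so they gave no view of this position, whereas this single change shows that inhibition here can depend heavily on which aromatic ring is attached, even when neither group carries a charge or a hydrogen-bond donor. Compound 3 reaches only a limit of the assay, so its actual number is unknown and the step is a minimum: the limit of > 100000 nM in this assay, at which 1 of the 3 values shown sits.

The values give no cause for the drop, and they leave open whether it follows from bringing in the thiophene or from losing the 3-fluorophenyl. An unsubstituted phenyl or a thiophen-3-yl at this place would help separate those two readings.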